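This account rests on a few compounds, and the source may have more. Where it says the series, first, only, none or still open, it means among the compounds named here.

Measured so far:

compound 1, `CCCSc1nc(N/N=C/c2ccccc2Cl)c2nnn(Cc3ccccc3)c2n1`: in a functional assay on MCF7 cells (Homo sapiens) for antiproliferative activity, read by MTT assay, with a stated time of 72 h (on this read-out lower numbers stand for stronger inhibition and higher numbers for weaker inhibition), compound 1 gives 13800 nM.
compound 2, `CCCSc1nc(N/N=C(\C)c2ccccc2O)c2nnn(Cc3ccccc3Cl)c2n1`: for compound 2 the value reported in this assay is a limit of the assay rather than a number, > 64000 nM.

Among the measured compounds shown here, compound 1 therefore holds the only actual number among the two values shown in this assay; the other value is a limit (the limit of > 64000 nM in this assay, at which 1 of the 2 values shown sits). For the measured compounds named here, nothing beyond that places compound 1 among its neighbours, since no two measured compounds differ in a single place.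

Compound 3, `CCCSc1nc(N/N=C(\C)c2ccc(Br)cc2)c2nnn(Cc3ccccc3)c2n1`, has not yet been tested. It differs from compound 1 in one place: a group of 10 heavy atoms (8 carbon, 1 nitrogen, 1 bromine; one six-membered aromatic ring of carbon only) in place of a group of 9 heavy atoms (7 carbon, 1 nitrogen, 1 chlorine; one six-membered aromatic ring of carbon only), on a nitrogen on an aromatic ring. The group that enters and the group that leaves are alike in kind, each carrying one six-membered aromatic ring of carbon only, one double bond outside aromatic rings and one hydrogen-bond acceptor, and the change sits on the same nitrogen on an aromatic ring. Going by the values given here, no measured pair repeats this change, so its size cannot be read from the data. The step from compound 1 to compound 3 is expected to be small, a 1.4-fold higher number from compound 1 to compound 3 (0.16 log units; within the scatter), and to stay within the usual scatter in this assay. Compound 3 is thus estimated at about 20000 nM, most likely between 6000 nM and 64000 nM.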

Compound 3, half-maximal inhibitory concentration: 13000 nM
Estimate against measurement, compound 3: 1.5-fold (0.19 log units) above; the measured number falls inside the stated range.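

This is the first pair shown that differs in one place, and so the first direct reading at this position, on a nitrogen on an aromatic ring. In this assay, a group of 10 heavy atoms carrying bromine takes the place of a group of 9 heavy atoms carrying chlorine, and the result is a 1.1-fold lower number from compound 1 to compound 3 (0.03 log units; within the scatter), so the two compounds read alike. The swap is one of like for like, since both groups hold one six-membered aromatic ring of carbon only and one double bond outside aromatic rings, but this single pair sets no rule, and nothing shown here gives a cause for the result.

Going by these compounds, whether the same tolerance would hold for a group of a different kind at this position, such as one ending in an amine or a carboxylic acid instead of the halogen-bearing carbon ring, stays open. Compound 2 stands at a limit of the assay, > 64000 nM, and it differs from compound 1 in more than one place, so it cannot show what any single change does.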